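The source may hold more compounds than are shown below. What is called first, only, known or untested is meant among the compounds shown, and "the series" means these compounds.

Three compounds share one core. Compound 1 `COc1cc(Cl)cc(-c2nn(-c3cccc(NC(=O)Nc4ccc(Cl)c(C(F)(F)F)c4)c3)cc2-c2ccncc2)c1` gives 98% in a functional assay on NCI-H322M cells (Homo sapiens) for inhibition, read by sulforhodamine B assay, with a stated time of 48 h, tested at 0.1 uM; on this read-out lower numbers stand for a stronger effect and higher numbers for a weaker effect at the one concentration tested. Compound 2 `COc1cc(Cl)cc(-c2nn(-c3cccc(NC(=O)Nc4ccc(Cl)c(Cl)c4)c3)cc2-c2ccncc2)c1` gives 90% in this assay, and compound 3 `COc1cc(Cl)cc(-c2nn(-c3cccc(NC(=O)Nc4cccc(C(F)(F)F)c4)c3)cc2-c2ccncc2)c1` gives 94% in this assay. Compound 3 stands second highest of the three numbers, with a number 4 percentage points lower from compound 1 to compound 3 (within the scatter) and a number 4 percentage points higher from compound 2 to compound 3 (within the scatter), so all three lie within the scatter of one another. Compound 4 `COc1cc(Cl)cc(-c2nn(-c3cccc(NC(=O)c4cccc(C(F)(F)F)c4)c3)cc2-c2ccncc2)c1` differs from compound 3 by 3-(trifluoromethyl)phenyl in place of (3-(trifluoromethyl)phenyl)amino on a carbonyl carbon. Among the measured compounds shown here, no measured step touches the carbonyl carbon or the amide-type nitrogen; the recorded steps exchange chloro, trifluoromethyl and hydrogen on an aromatic carbon, and none moves the read-out beyond the scatter. Compound 4 is therefore expected to show a number 1 percentage points higher from compound 3 to compound 4 (within the scatter), which is no step beyond the scatter. The estimate for compound 4 is 95%, between 84% and 106%.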

Compound 4, a percentage reported as activity, at one concentration (the size of the read-out at that concentration, not a potency): 95%
For compound 4 middle estimate and measured number coincide at the digits printed; the range from low to high includes it.
By their numbers in this assay, from the lowest: compounds 2, 3, 4 and 1 (each within the scatter of the next).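

Among the compounds shown here, with the first step at this carbonyl carbon, 3-(trifluoromethyl)phenyl replaces (3-(trifluoromethyl)phenyl)amino, removing the amino nitrogen and its hydrogen, and this assay shows a number 1 percentage points higher from compound 3 to compound 4 (within the scatter). The changes from the other two compounds give a number 5 percentage points higher from compound 2 to compound 4 (within the scatter) and a number 3 percentage points lower from compound 1 to compound 4 (within the scatter), so none of the three exchanges at this position moves the read-out beyond the scatter. No measurement shown accounts for this result.
As far as these compounds go, whether an amine, a carboxylic acid or a longer chain on this carbonyl carbon would move the number beyond the scatter stays open.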